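Working notes on the series: compound 3 to compound 4

A few compounds are considered here, and "the series" means these few. Any claim that something is new, unique, unknown or untested is made for them only; others in the source may bear on it.

Measured compounds:
compound 1 `CC(C)C[C@H](N)CN(C(=O)[C@@H]1C[C@H]1c1ccccc1)c1ccc(-c2ccccc2)cc1` gives 880 nM
compound 2 `CC[C@H](C)[C@H](N)CN(C(=O)[C@@H]1C[C@H]1c1csc(C)n1)c1ccc(-c2ccccc2)cc1` gives 1500 nM
compound 3 `CC[C@H](C)[C@H](N)CN(C(=O)[C@@H]1C[C@H]1c1ccccc1)c1ccc(-c2ccc(COC)cc2)cc1` gives 35 nM

All three numbers come from a functional assay for agonist activity at G protein-coupled receptor 88 (Homo sapiens), read by HTRF and cAMP accumulation; on this read-out higher numbers stand for an effect only at larger amounts of compound and lower numbers for an effect already at smaller amounts. Among them compound 3 stands lowest; compound 1 lies at the nearer higher number and compound 2 at the furthest, and both of those gaps are beyond the scatter, so compound 3 is the most potent of the three measured compounds. Compound 3 also differs from compound 1 and compound 2 in more than one place, so no single change can be read from these values.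

The next compound, compound 4 `CC[C@H](C)[C@H](N)CN(C(=O)[C@@H]1C[C@H]1c1ccccc1)c1ccc(-c2ccc(CN)cc2)cc1`, keeps everything of compound 3 except one change: amino in place of methoxy on a saturated chain carbon bound to an aromatic carbon. Going by the values given here, no pair of measured compounds shows this change, so its direction is not anchored by any number in hand. The swap keeps the group small and keeps one hydrogen-bond acceptor, adding a donor, and the rest of the shared core is untouched. The expected step from compound 3 to compound 4 is therefore small, a 1.7-fold higher number from compound 3 to compound 4 (0.23 log units; within the scatter), leaning toward a somewhat higher number but not clearly beyond the scatter. Compound 4 is thus estimated at 60 nM in this assay, with a range from 15 nM to 250 nM.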

Compound 4, half-maximal effective concentration: > 30000 nM
Compound 4: a limit, no number; the forecaster's own chance of this, stated with the estimate: 5%; middle value at least 500-fold (2.69 log units) from the limit.
By their numbers in this assay, from the lowest: compound 3; then compounds 1 and 2 (each within the scatter of the next). At a limit, above all of these: compound 4.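

In this assay compound 4 gives > 30000 nM, which is a limit of the assay and not a number: the limit of > 30000 nM in this assay, at which 1 of the 4 values shown sits. Going by these compounds alone, this pair provides the first change at a single place, and amino in place of methoxy on a saturated chain carbon bound to an aromatic carbon gives an at least 850-fold higher number from compound 3 to compound 4 (2.93 log units; beyond the scatter), so the end of this side chain can decide the read-out on an otherwise unchanged core. The earlier compounds shown here could not show this, as they differ from each other in more than one place; here a swap of methoxymethyl to aminomethyl alone takes the compound from the lowest number to the limit.

Going by these compounds, whether the loss follows from the amino group itself, or would also occur with another replacement for methoxy, stays open, as hydroxy, dimethylamino and a longer ether such as ethoxy at this place would be needed to tell these apart. Also open, on these data alone, is what 4-(methoxymethyl)phenyl gives against a plain phenyl on this same core, and whether the amino change acts the same way on the core of compound 1.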